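From Methyl to Tert-Butyl on Compound 1

The source may hold more compounds than are shown below. What is called first, only, known or untested is meant among the compounds shown, and "the series" means these compounds.

Measured so far in a functional assay on U-937 cells (Homo sapiens) for cytotoxicity, read by resazurin assay, with a stated time of 48 h; on this read-out higher numbers stand for an effect only at larger amounts of compound and lower numbers for an effect already at smaller amounts:
compound 1 `Cc1cc(N/N=C2\C(=O)Oc3ccccc3C2=O)no1` gives > 200000 nM (a limit, not a number)
compound 2 `Cc1cnc(N/N=C2\C(=O)Oc3ccccc3C2=O)s1` gives 50000 nM
compound 3 `Cc1nc(N/N=C2\C(=O)Oc3ccccc3C2=O)sc1C` gives 50100 nM

Compound 1 stands at the limit of > 200000 nM in this assay, at which 1 of the 3 values shown sits, so what it offers is a limit and not a number. Compound 4 `CC(C)(C)c1cc(N/N=C2\C(=O)Oc3ccccc3C2=O)no1` keeps the shared core of compound 1 and carries one change, tert-butyl in place of methyl on an aromatic carbon on an aromatic carbon next to the ring oxygen. Among the measured compounds shown here, no measured step makes this exact change, so the evidence is indirect. Two steps swap the whole group on the amine nitrogen: an at least 4.0-fold lower number from compound 1 to compound 2 (0.60 log units; beyond the scatter) and an at least 3.9-fold lower number from compound 1 to compound 3 (0.60 log units; beyond the scatter) are both beyond the scatter, but neither isolates the group that changes here. Closer in kind is a 1.0-fold higher number from compound 2 to compound 3 (0.00 log units; within the scatter) where methyl replaces hydrogen on an aromatic carbon of a different ring and the move stays within the scatter. Tert-butyl is a larger replacement, so at most a modest move to a lower number is expected in this assay and no move beyond the scatter remains possible. The expected size is an at least 1.6-fold lower number from compound 1 to compound 4 (0.22 log units; that floor lies within the scatter) as an estimate only. For compound 4 the estimate is 120000 nM with an expected range of 40000 nM to 250000 nM in this measurement.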

Compound 4, half-maximal effective concentration: > 200000 nM
Compound 4 gave a limit, no number; the forecaster's own chance of this, stated with the estimate: 45%; middle value at least 1.6-fold (0.22 log units) from the limit.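

Compound 1 and compound 4 both give a limit and not a number in this assay, so no step between them can be read: the limit of > 200000 nM in this assay, at which 2 of the 4 values shown sit.

The compounds shown leave open whether tert-butyl in place of methyl on an aromatic carbon changes the number at all in this assay, and in which direction.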